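Chloro in place of fluoro on the phenyl ring

The source may report more compounds than this note shows. Statements on the series, on what has been measured and on what is new or still open speak of the compounds shown alone.

compound 1 `C=CC(=O)Nc1cc(Nc2ncc3ncn(-c4ccc(F)cc4)c3n2)c(OC)cc1N(C)CCN(C)C` — 12000 nM
compound 2 `C=CC(=O)Nc1cc(Nc2ncc3ncn(-c4ccccc4F)c3n2)c(OC)cc1N(C)CCN(C)C` — 9750 nM

Of the compounds shown here, two have been measured in an ADME assay on HT-29 cells (Homo sapiens) for cytotoxicity, read by MTT assay, with a stated time of 72 h (on this read-out lower numbers stand for stronger inhibition and higher numbers for weaker inhibition), so far. Compound 1 gives 12000 nM and compound 2 gives 9750 nM. Among the measured compounds shown here, the only measured step, 2-fluorophenyl in place of 4-fluorophenyl on an aromatic nitrogen, reads a 1.2-fold lower number from compound 1 to compound 2 (0.09 log units; within the scatter), so compound 2 stands beside compound 1 with no separation beyond the scatter.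

Compound 3 `C=CC(=O)Nc1cc(Nc2ncc3ncn(-c4ccccc4Cl)c3n2)c(OC)cc1N(C)CCN(C)C` is not yet measured. It differs from compound 2 in one place: chloro in place of fluoro on an aromatic carbon. For the measured compounds named here, the one measured step bears on this change only in that it also moved a halogen on the same phenyl ring, and it was within the scatter. No step beyond the scatter in this assay is therefore expected. Compound 3 is expected to give about 9000 nM, within 4000 nM to 20000 nM. This amounts to an expected step of a 1.1-fold lower number from compound 2 to compound 3 (0.03 log units; within the scatter).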

Compound 3, half-maximal inhibitory concentration: 11300 nM
The estimate for compound 3 lay 1.3-fold (0.10 log units) below the measured number, within the range that was stated.
By their numbers in this assay, from the lowest: compounds 2, 3 and 1 (each within the scatter of the next).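

In this assay, among the compounds shown here, the first halogen exchange at this position, chloro in place of fluoro on an aromatic carbon ortho to a large group, gives a 1.2-fold higher number from compound 2 to compound 3 (0.06 log units; within the scatter). The 2-chlorophenyl group in place of the 4-fluorophenyl group gives a 1.1-fold lower number from compound 1 to compound 3 (0.03 log units; within the scatter), so across these three compounds neither the identity of the halogen nor the two ring placements shown separates the values beyond the scatter. No evidence is available that would explain this lack of separation.

The compounds shown leave open whether an amine, a methoxy group or a carboxylic acid on this phenyl ring would give a number separated from those of the three halogen compounds in this assay. They also leave open how the unsubstituted phenyl group would compare with them.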